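This account rests on a few compounds, and the source may have more. Where it says the series, first, only, none or still open, it means among the compounds named here.

In an ADME assay on microsomes from liver (Homo sapiens) for metabolic stability (on this read-out lower numbers stand for slow clearance and higher numbers for fast clearance), compound 3 `O=C(N[C@H]1CN(S(=O)(=O)c2ccccc2)C[C@@H]1C(=O)NC[C@@H]1CCCN1)c1cc(-c2ccccc2Cl)on1` gives 9.7 mL.min-1.g-1 and compound 2 `O=C(N[C@H]1CN(S(=O)(=O)c2ccccc2)C[C@@H]1C(=O)N[C@H]1CCCNC1)c1ccc(-c2cc(C(F)(F)F)ccc2Cl)o1` gives 5.5 mL.min-1.g-1, two values within the scatter of each other. Compound 1 `O=C(N[C@H]1CN(S(=O)(=O)c2ccccc2)C[C@@H]1C(=O)N[C@H]1CCCNC1)c1cc(-c2ccccc2Cl)on1` gives < 3 mL.min-1.g-1, which is a limit of the assay. The change now followed leads to compound 4 `CN1CCC[C@H](NC(=O)[C@H]2CN(S(=O)(=O)c3ccccc3)C[C@@H]2NC(=O)c2cc(-c3ccccc3Cl)on2)C1`, with 1-methylpiperidin-3-yl in place of (pyrrolidin-2-yl)methyl on an amide-type nitrogen. Going by the values given here, one measured step bears on this: (pyrrolidin-2-yl)methyl in place of piperidin-3-yl at that same nitrogen gave an at least 3.2-fold higher number from compound 1 to compound 3 (0.50 log units; beyond the scatter), beyond the scatter. Going by these compounds, a partial reversal of that step is therefore expected, though the added methyl is untested here. The expected change is a 1.9-fold lower number from compound 3 to compound 4 (0.29 log units; within the scatter), towards a lower number. Compound 4 is estimated at 5 mL.min-1.g-1, with an expected range of 2.5 mL.min-1.g-1 to 12 mL.min-1.g-1.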

Compound 4, intrinsic clearance in microsomes: 106 mL.min-1.g-1
Compound 4: middle estimate off by 21-fold (1.33 log units), on the low side; measured number outside the range, above it.
By their numbers in this assay, from the lowest: compounds 2 and 3 (each within the scatter of the next); then compound 4. At a limit, below all of these: compound 1.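

In this assay, methyl in place of hydrogen on the amine nitrogen in the ring gives an at least 35-fold higher number from compound 1 to compound 4 (1.54 log units; beyond the scatter), so the low number of the piperidin-3-yl compound does not survive this single addition. The 1-methylpiperidin-3-yl group also stands well clear of (pyrrolidin-2-yl)methyl, with an 11-fold higher number from compound 3 to compound 4 (1.04 log units; beyond the scatter), which the earlier step between the two unmethylated groups did not foretell. Compound 1 sits at a limit, so the first step gives only a bound: the limit of < 3 mL.min-1.g-1 in this assay, at which 1 of the 4 values shown sits.

Going by these compounds, whether an ethyl or acetyl group on that ring nitrogen acts as methyl does remains open. So does whether methyl on the ring nitrogen of the (pyrrolidin-2-yl)methyl group of compound 3 brings a similar rise.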